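Phenyl to 4-cyanophenyl on the compound 2 sulfonamide

The compounds below may be only part of what the source reports. "The series", "measured", "known", "first", "only" and "open" are said of these compounds alone.

Values in a functional assay on MDA-MB-436 cells (Homo sapiens) for antiproliferative activity, read by MTT assay, with a stated time of 24 h; a lower number here means a stronger inhibitor, a higher number a weaker inhibitor:
- compound 1 `O=C(O)CC(NC(=O)c1ccc(Cl)cc1Cl)c1ccccc1F`: > 100000 nM, a limit
- compound 2 `O=C(O)CC(NS(=O)(=O)c1ccccc1)c1ccc(Cl)cc1Cl`: 59000 nM
- compound 3 `O=C(O)CC(NS(=O)(=O)c1cccc([N+](=O)[O-])c1)c1ccc(Cl)cc1Cl`: > 100000 nM, a limit

Going by the values given here, compound 2 gives the only actual number in this set, 59000 nM. The other two values are not numbers: the limit of > 100000 nM in this assay, at which 2 of the 3 values shown sit.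

Compound 4 `N#Cc1ccc(S(=O)(=O)NC(CC(=O)O)c2ccc(Cl)cc2Cl)cc1` differs from compound 2 by cyano in place of hydrogen on an aromatic carbon, para to a large group: cyano in place of hydrogen on an aromatic carbon.

Among the compounds with values here, the one measured step that bears on this is nitro in place of hydrogen on an aromatic carbon, an at least 1.6-fold higher number from compound 2 to compound 3 (0.22 log units; that floor lies within the scatter). On that basis, a small move to a higher number is expected in this assay, possibly no larger than the scatter. For compound 4 the estimate is 75000 nM, with an expected range of 35000 nM to 140000 nM. The estimated step is a 1.3-fold higher number from compound 2 to compound 4 (0.10 log units; within the scatter).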

Compound 4, half-maximal inhibitory concentration: 19800 nM
Compound 4: middle estimate off by 3.8-fold (0.58 log units), on the high side, and the stated range ends above it.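

In this assay, the sulfonamide phenyl ring accepts a change at the place para to a large group that gives a lower number, with cyano in place of hydrogen: a 3.0-fold lower number from compound 2 to compound 4 (0.47 log units; beyond the scatter). This is the only step shown on this ring that lowers the number beyond the scatter. The nitro step goes against any general reading of substitution on this ring, and its true size stays unknown: the limit of > 100000 nM in this assay, at which 2 of the 4 values shown sit.

Open, on these data alone, is whether an amine or a carboxylic acid at the same place would follow cyano. Also open, as far as these compounds go, is whether cyano keeps this step at another place on the ring.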